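The source may hold more compounds than are shown below. What is called first, only, known or untested is meant among the compounds shown, and "the series" means these compounds.

Compound 1 `O=C(CCC(=O)OCCCCCCSc1ccc([N+](=O)[O-])c2nonc12)Nc1ccccc1Cl`: 2750 nM
Compound 2 `O=C(CCC(=O)OCCCCCCSc1ccc([N+](=O)[O-])c2nonc12)Nc1cccc(Cl)c1`: 5290 nM
Compound 3 `O=C(CCC(=O)OCCCCCCSc1ccc([N+](=O)[O-])c2nonc12)Nc1ccc(Br)cc1`: 3340 nM

All three were tested in a functional assay on A549 cells (Homo sapiens) for inhibition, read by MTT assay, with a stated time of 72 h; a higher number here means a weaker inhibitor, a lower number a stronger inhibitor. They share one core and differ only in the group on the amide-type nitrogen. Compound 1 gives the smallest number of the three, yet a 1.9-fold higher number from compound 1 to compound 2 (0.28 log units; within the scatter) and a 1.2-fold higher number from compound 1 to compound 3 (0.08 log units; within the scatter) are both within the scatter, as is a 1.6-fold lower number from compound 2 to compound 3 (0.20 log units; within the scatter), so the three cannot be ranked. Compound 4 `CN(C)CCNC(=O)CCC(=O)OCCCCCCSc1ccc([N+](=O)[O-])c2nonc12` has not been measured. Its difference from compound 1 is 2-(dimethylamino)ethyl in place of 2-chlorophenyl on an amide-type nitrogen. Within the data shown here, no measured step exchanges a ring-bearing group for a chain on this nitrogen; the three measured steps only swap one substituted phenyl for another, and none moved the number beyond the scatter. There is therefore no basis for expecting a particular direction, and the number for compound 4 is expected to stay near that of compound 1, with wide uncertainty: a 1.3-fold higher number from compound 1 to compound 4 (0.10 log units; within the scatter). The estimate for compound 4 in this assay is 3500 nM, between 1200 nM and 12000 nM.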

Compound 4, half-maximal inhibitory concentration: 5550 nM
Beside the measured number, compound 4's estimate is 1.6-fold (0.20 log units) below it; the measured number falls inside the stated range.
By their numbers in this assay, from the lowest: compounds 1, 3, 2 and 4 (each within the scatter of the next).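

Swapping the aromatic ring on this amide-type nitrogen for a chain, 2-(dimethylamino)ethyl, is a different kind of change from the earlier phenyl-for-phenyl swaps, yet in this assay there is a 2.0-fold higher number from compound 1 to compound 4 (0.30 log units; within the scatter) and a 1.7-fold higher number from compound 3 to compound 4 (0.22 log units; within the scatter) and a 1.0-fold higher number from compound 2 to compound 4 (0.02 log units; within the scatter). Among these four compounds, then, a ring on this nitrogen is not needed for a number within the scatter of the others. Nothing measured here explains this result. Still open, as far as these compounds go, is whether a plain hexyl chain, a carboxylic acid or a morpholine on this nitrogen would move the number beyond the scatter.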